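The compounds below may be only part of what the source reports. "The series", "measured", "known", "first", "only" and "open" are said of these compounds alone.

Compound 1 `CN(C)c1ccc(/C=C2\CCC/C(=C\c3ccccc3[N+](=O)[O-])C2=O)cc1` gives the highest number of the three measured compounds in a functional assay on CCRF-CEM cells (Homo sapiens) for cytotoxicity, with a stated time of 72 h (on this read-out lower numbers stand for stronger inhibition and higher numbers for weaker inhibition), at 168000 nM. Its nearest neighbour, compound 3 `CN(C)c1ccc(/C=C2\CCC/C(=C\c3cccc([N+](=O)[O-])c3)C2=O)cc1`, gives 11700 nM, and compound 2 `O=C1/C(=C/c2ccc(Cl)cc2)CCC/C1=C\c1ccc([N+](=O)[O-])cc1` gives 8180 nM. Among the measured compounds shown here, the one single-point step on record, a 14-fold lower number from compound 1 to compound 3 (1.16 log units; beyond the scatter), concerns the position of the nitro group and not the change now in question. Compound 4 `O=C1/C(=C/c2ccc(F)cc2)CCC/C1=C\c1ccccc1[N+](=O)[O-]` differs from compound 1 as fluoro in place of dimethylamino on an aromatic carbon. For the measured compounds named here, no measured step tests this exchange directly; compound 2 carries a halogen but also a differently placed nitro group, so its lower value can only hint that a large, or at least moderate, move toward stronger inhibition is plausible. The number for compound 4 is therefore expected to show a 4.8-fold lower number from compound 1 to compound 4 (0.68 log units; beyond the scatter), estimated at 35000 nM within 9000 nM to 130000 nM.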

Compound 4, half-maximal inhibitory concentration: 1510 nM
Estimate against measurement, compound 4: 23-fold (1.37 log units) above; measured number outside the range, below it.
By their numbers in this assay, from the lowest: compound 4; then compounds 2 and 3 (each within the scatter of the next); then compound 1.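

In this assay, among the compounds shown here, fluoro in place of dimethylamino on an aromatic carbon gives a 110-fold lower number from compound 1 to compound 4 (2.05 log units; beyond the scatter), the only direct reading of this exchange. With the 2-nitrophenyl group held fixed, the change from 4-(dimethylamino)phenyl to 4-fluorophenyl alone produces a large step. Nothing available accounts for the size of this step. Going by these compounds, it remains open whether the step reflects losing dimethylamino or gaining fluoro, which hydrogen, chloro or methoxy at this place could help separate. On these data alone, it also remains open whether the exchange behaves alike with 3-nitrophenyl in place of 2-nitrophenyl.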